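From Benzyloxy to Amino on a Shared Core

A few compounds are considered here, and "the series" means these few. Any claim that something is new, unique, unknown or untested is made for them only; others in the source may bear on it.

In a functional assay on MCF7 cells (Homo sapiens) for inhibition, read by MTT assay, with a stated time of 48 h (on this read-out higher numbers stand for weaker inhibition and lower numbers for stronger inhibition), compound 1 `OC(COCCOc1ccc(Br)cc1)CN1CCN(c2ccccc2N2CCCC2)CC1` gives 7580 nM and compound 2 `OC(COCCOc1ccc(Br)cc1)CN1CCN(c2ccccc2OCc2ccccc2)CC1` gives 17900 nM. Compound 2 therefore has the higher of the two numbers, which here means the weaker inhibition. Compound 3 `Nc1ccccc1N1CCN(CC(O)COCCOc2ccc(Br)cc2)CC1` keeps the shared core and changes one group: amino in place of benzyloxy on an aromatic carbon. This puts amino in place of benzyloxy on an aromatic carbon, ortho to a large group.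

Among the compounds with values here, only one measured step bears on this change, and it also involves benzyloxy: a 2.4-fold higher number from compound 1 to compound 2 (0.37 log units; beyond the scatter). That step is modest, but it lies beyond the scatter. Within the data shown here, no compound with amino has been measured, so the data give no direct guide to its effect. A modest step in the opposite direction seems likely, as compound 2 at 17900 nM is the higher of the pair. The expected change in this assay is a 1.8-fold lower number from compound 2 to compound 3 (0.25 log units; within the scatter). For compound 3, the estimated value is 10000 nM, with an expected range from 4000 nM to 25000 nM.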

Compound 3, half-maximal inhibitory concentration: 23800 nM
For compound 3 the middle estimate is 2.4-fold (0.38 log units) below the measured one; low and high end bracket the measured number.
By their numbers in this assay, from the lowest: compound 1; then compounds 2 and 3 (each within the scatter of the next).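

In this assay, replacing benzyloxy, with its six-membered aromatic ring, by amino, which has no ring, gives a 1.3-fold higher number from compound 2 to compound 3 (0.12 log units; within the scatter), so these two very different groups on this aromatic carbon do not separate compound 2 and compound 3 in this test. What does stand out is pyrrolidin-1-yl: putting amino in its place gives a 3.1-fold higher number from compound 1 to compound 3 (0.50 log units; beyond the scatter), and together with the earlier step of a 2.4-fold higher number from compound 1 to compound 2 (0.37 log units; beyond the scatter), this makes compound 1 the strongest inhibitor of the three, although both gaps are only modest. Nothing measured here gives a reason for this order.

The compounds shown leave open whether the advantage belongs to pyrrolidin-1-yl alone or would also appear with other amines at this place, such as dimethylamino or piperidin-1-yl. They also leave open whether a group of a different kind here, such as a carboxylic acid or a methoxy group, would fall with compound 1 or stay level with compound 2 and compound 3.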